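Sulfamoyl for carbamoyl: expected cytotoxicity of compound 3

The source may report more compounds than this note shows. Statements on the series, on what has been measured and on what is new or still open speak of the compounds shown alone.

Measured so far in an ADME assay on Vero cells (Chlorocebus sabaeus) for cytotoxicity, read by MTT assay, with a stated time of 72 h; a higher number here means a weaker inhibitor, a lower number a stronger inhibitor:
- compound 1 `COc1ccc(-c2ccnc(Nc3cccc(S(N)(=O)=O)c3)n2)cc1` gives 1100 nM as its value
- compound 2 `COc1ccc(-c2ccnc(Nc3ccc(C(N)=O)cc3)n2)cc1` gives 5400 nM as its value

Among the compounds with values here, of these two numbers, the one for compound 2 is the higher. At 5400 nM in this assay compound 2 stands above compound 1, and the gap between the two lies beyond the usual scatter. The next compound to be read is compound 3 `COc1ccc(-c2ccnc(Nc3ccc(S(N)(=O)=O)cc3)n2)cc1`, which has sulfamoyl in place of carbamoyl on an aromatic carbon, para to a large group sulfamoyl in place of carbamoyl on an aromatic carbon and is otherwise the same as compound 2.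

Within the data shown here, no measured pair shows this exchange on its own, so the expectation rests on thin evidence. Compound 1, which also carries a sulfamoyl, gives 1100 nM in this assay and so points towards a lower number. A modest drop, close to the edge of the scatter, is therefore expected, and the estimated change is a 2.2-fold lower number from compound 2 to compound 3 (0.33 log units; beyond the scatter) in this assay with wide uncertainty. For compound 3 the estimated value is 2500 nM with an expected range from 800 nM to 8000 nM for the coming measurement.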

Compound 3, half-maximal inhibitory concentration: 2400 nM
For compound 3 the middle estimate is 1.0-fold (0.02 log units) above the measured one; low and high end bracket the measured number.
By their numbers in this assay, from the lowest: compound 1; then compound 3; then compound 2.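

With compound 3, the exchange has its first direct reading in this assay: sulfamoyl in place of carbamoyl on an aromatic carbon, para to a large group, gives a 2.3-fold lower number from compound 2 to compound 3 (0.35 log units; beyond the scatter), a modest step with the rest of the structure unchanged. Within the data shown here, until now, the only sulfamoyl compound carried the group at a different place on the aromatic ring, so the two groups had not been read against each other at one position; with the position shared, compound 3 gives 2400 nM, while compound 1, with its sulfamoyl elsewhere, gives 1100 nM as its value in this assay. Nothing available accounts for the direction or size of this step.

From the compounds shown here alone, this is a single pair, so how far the step carries to other positions or to changes elsewhere on the shared core remains open. Also open, going by these compounds, is how a carboxylic acid, a methylsulfonyl group or a primary amine at the same position would read against carbamoyl and sulfamoyl, and whether the step would hold with carbamoyl at the place the sulfamoyl occupies in compound 1.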